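This account rests on a few compounds, and the source may have more. Where it says the series, first, only, none or still open, it means among the compounds named here.

Working notes on the series.

Three measured compounds share one core and differ at a single aromatic carbon. Compound 1 `CNC(=O)c1cc(Oc2ccc(NC(=O)c3cc(-c4ccc(F)cc4)ncn3)cc2F)ccn1` carries fluoro at that position; in a functional assay on MCF7 cells (Homo sapiens) for cytotoxicity, read by MTT assay, with a stated time of 72 h (on this read-out lower numbers stand for stronger inhibition and higher numbers for weaker inhibition), compound 1 gives > 100000 nM, which is a limit of the assay and not a number. Compound 3 `CNC(=O)c1cc(Oc2ccc(NC(=O)c3cc(-c4ccc(C(F)(F)F)cc4)ncn3)cc2F)ccn1` carries trifluoromethyl in place of fluoro on an aromatic carbon; in this assay compound 3 gives > 100000 nM, again a limit. The step that the two limits leave unreadable from compound 1 to compound 3 is consequently of unreadable size because both of its values sit at the limit of > 100000 nM in this assay, at which 3 of the 3 values shown sit. Compound 2 `CNC(=O)c1cc(Oc2ccc(NC(=O)c3cc(-c4ccc(Cl)cc4)ncn3)cc2)ccn1` carries chloro at the same position; in this assay compound 2 gives > 100000 nM, likewise a limit. Compound 2 therefore stands at the same limit as the two other values shown, and the numbers do not separate any of the three.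

Compound 4 `CNC(=O)c1cc(Oc2ccc(NC(=O)c3cc(-c4ccccc4)ncn3)cc2)ccn1` has not been measured. It differs from compound 2 by hydrogen in place of chloro on an aromatic carbon, that is, 4-chlorophenyl to phenyl. Going by the values given here, no measured step of this kind exists, and the single step available, from fluoro to trifluoromethyl, reads as unreadable in size. Nothing in the three values suggests movement off the limit, so no step beyond the scatter is expected. The step that the limit leaves unreadable from compound 2 to compound 4 is accordingly expected to be flat. For compound 4 the estimate in this assay is 150000 nM, within a range from 50000 nM to 500000 nM.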

Compound 4, half-maximal inhibitory concentration: 18200 nM
Beside the measured number, compound 4's estimate is 8.2-fold (0.92 log units) above it, and the stated range ends above it.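

Hydrogen in place of chloro on an aromatic carbon, para to a large group, is the first change at this position to register in this assay, giving an at least 5.4-fold lower number from compound 2 to compound 4 (0.73 log units; beyond the scatter) in a single matched pair. The position therefore does respond to substitution, at least for this pair, whereas the step from fluoro to trifluoromethyl cannot be read and gave no sign of that. The step from chloro to hydrogen stays a bound and not a measured size because compound 2 remains at the limit, as do the other two substituted compounds: the limit of > 100000 nM in this assay, at which 3 of the 4 values shown sit.

The shown compounds leave open how far the change itself reaches, since only compound 4 has a number and no step links it to compound 1 or compound 3, which differ from it in more than one place. Whether a methoxy group, an amine or a carboxylic acid on this aromatic carbon would also come off the limit, or whether hydrogen alone does so, remains unanswered.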